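A few compounds are considered here, and "the series" means these few. Any claim that something is new, unique, unknown or untested is made for them only; others in the source may bear on it.

Compound 1 `CCn1c(C(=O)NC(C)(C)CO)ccc1C(CC)(CC)c1ccc(OCS(=O)(=O)c2ccccc2)c(C)c1`: 20700 nM
Compound 2 `CCn1c(C(=O)NCCCO)ccc1C(CC)(CC)c1ccc(OCS(=O)(=O)c2ccccc2)c(C)c1`: 42000 nM

In a functional assay on MCF7 cells (Homo sapiens) for antiproliferative activity, read by MTT assay, with a stated time of 24 h (on this read-out higher numbers stand for weaker inhibition and lower numbers for stronger inhibition), compound 2 gives 42000 nM, the higher of the two numbers and so the weaker inhibition. Compound 3 `CCn1c(C(=O)N[C@@H](CO)CCO)ccc1C(CC)(CC)c1ccc(OCS(=O)(=O)c2ccccc2)c(C)c1` differs from it by one change: hydroxymethyl in place of hydrogen on a saturated chain carbon bound to an amide-type nitrogen and a saturated chain carbon, (hydroxymethyl in place of hydrogen on a saturated chain carbon bound to an amide-type nitrogen and a saturated chain carbon). Among the measured compounds shown here, only one measured step involves this side chain: a 2.0-fold higher number from compound 1 to compound 2 (0.31 log units; beyond the scatter). That modest step is thin evidence, so only a small move towards a lower number is expected, perhaps no larger than the scatter. The expected step is a 1.4-fold lower number from compound 2 to compound 3 (0.15 log units; within the scatter). The estimated value for compound 3 is 30000 nM, within a range of 12000 nM to 70000 nM.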

Compound 3, half-maximal inhibitory concentration: 27400 nM
Compound 3: the middle estimate sits 1.1-fold (0.04 log units) above what was measured, within the range that was stated.
By their numbers in this assay, from the lowest: compounds 1, 3 and 2 (each within the scatter of the next, the first and the last beyond it).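

In this assay, adding hydroxymethyl gives a 1.5-fold lower number from compound 2 to compound 3 (0.19 log units; within the scatter) and so does not separate the two compounds. Replacing 1-(hydroxymethyl)-1-methylethyl with 3-hydroxy-1-(hydroxymethyl)propyl gives a 1.3-fold higher number from compound 1 to compound 3 (0.12 log units; within the scatter) and also falls short of a clear difference, so this side chain accepts the extra hydroxymethyl without a readable change in the number. Nothing measured here offers a reason for these numbers. All three side chains shown carry hydroxyl groups, so it remains open how an amine, a carboxylic acid or a longer chain at this amide-type nitrogen would read.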